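The compounds below may be only part of what the source reports. "The series", "measured", "known", "first", "only" and "open" are said of these compounds alone.

Compound 1 `CCCCCCCCOc1cccc(O)c1C(=O)/C=C/c1ccc(O)cc1` and compound 2 `CCCCC/C=C\CCCCOc1cccc(O)c1C(=O)/C=C/c1ccc(O)cc1` share one core and differ only in the chain on an oxygen on an aromatic ring. In an ADME assay on RAW264.7 cells (Mus musculus) for cytotoxicity, read by MTT assay (on this read-out lower numbers stand for stronger inhibition and higher numbers for weaker inhibition), compound 1 gives > 30000 nM, which is a limit of the assay and not a number. In this assay compound 2 gives > 30000 nM, also a limit, so compound 2 has no exact value. The record so far is the limit of > 30000 nM in this assay, at which 2 of the 2 values shown sit. Compound 3 `O=C(/C=C/c1ccc(O)cc1)c1c(O)cccc1OCc1ccccc1` differs from compound 2 by one change: phenyl in place of dec-4-en-1-yl on a saturated chain carbon bound to an oxygen on an aromatic ring. Within the data shown here, the only measured step bearing on this chain is a step that the two limits leave unreadable from compound 1 to compound 2, and it offers no size to carry over. No clear shift in either direction is therefore expected in this assay. The expected step is a step that the limit leaves unreadable from compound 2 to compound 3. For compound 3 the estimated value is 40000 nM, with an expected range of 15000 nM to 100000 nM.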

Compound 3, half-maximal inhibitory concentration: > 30000 nM
Compound 3: no number, only a limit; the forecaster's own chance of this, stated with the estimate: 80%; the middle value does not contradict the limit.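

Among these compounds, compound 3 gives only a limit of the assay and not a number, so no step among compound 1, compound 2 and compound 3 can be read in this assay. All three share one result: the limit of > 30000 nM in this assay, at which 3 of the 3 values shown sit.

On these data alone, what remains open is whether changing this chain alters cytotoxicity at all, and by how much.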